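The source may report more compounds than this note shows. Statements on the series, on what has been measured and on what is new or still open speak of the compounds shown alone.

Of the compounds shown here, three sharing one core have been read in a physicochemical assay for solubility, read by HPLC, in phosphate buffer, with a stated time of 24 h, at pH 7.4, tested at 100 uM; on this read-out lower numbers stand for lower solubility and higher numbers for higher solubility. Compound 1 `O=C(CCCCCNc1c(Nc2ccccc2)c(=O)c1=O)NO` gives 47000000 nM, compound 2 `COc1cc(Nc2c(NCCCCCC(=O)NO)c(=O)c2=O)ccc1N(C)C` gives 93000000 nM, and compound 3 `CC(CCCCC(=O)NO)Nc1c(Nc2ccccc2)c(=O)c1=O` gives 93000000 nM. Compound 3 thus stands level with compound 2 and within the scatter of compound 1.

Compound 4 `CC(CCCCC(=O)NO)Nc1c(Nc2ccc(C(F)(F)F)cc2)c(=O)c1=O` departs from compound 3 at one place: trifluoromethyl in place of hydrogen on an aromatic carbon. This is trifluoromethyl in place of hydrogen on an aromatic carbon, para to a large group.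

Within the data shown here, only one measured step bears on this change, and only indirectly. a 2.0-fold higher number from compound 1 to compound 3 (0.30 log units; within the scatter) stays within the scatter, but it concerns a saturated chain carbon, not the aromatic ring. Compound 2 does carry other groups on its aromatic ring and shows 93000000 nM, yet it differs from compound 3 in more than one place. Among the measured compounds shown here, no measured step places trifluoromethyl on the ring, so the data offer no direct guide and the expectation remains a judgement with a wide range. A moderate move towards a lower number in this assay is expected. The estimated step is a 3.7-fold lower number from compound 3 to compound 4 (0.57 log units; beyond the scatter). Compound 4 is expected at 25000000 nM, with an estimated range of 6000000 nM to 70000000 nM.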

Compound 4, solubility: 30000000 nM
Compound 4: middle estimate off by 1.2-fold (0.08 log units), on the low side; low and high end bracket the measured number.
By their numbers in this assay, from the lowest: compounds 4, 1, 2 and 3 (each within the scatter of the next, the first and the last beyond it).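

In this assay the aromatic ring proves to be a place where a single change can carry the number beyond the scatter: trifluoromethyl in place of hydrogen on an aromatic carbon, para to a large group, gives a 3.1-fold lower number from compound 3 to compound 4 (0.49 log units; beyond the scatter) and the step is modest in size. Among these compounds, the only earlier one-place step, a 2.0-fold higher number from compound 1 to compound 3 (0.30 log units; within the scatter), lay on a saturated chain carbon and stayed within the scatter, so the ring had not been tested by any step until now. No measurement at hand speaks to why the number falls with this change.

The compounds shown leave open whether a different group at this same place, such as a fluorine, a methoxy, an amine or a carboxylic acid, would move the number in the same direction or the opposite one. They also leave open whether trifluoromethyl would give a step of like size without the chain methyl of compound 3, as in compound 1, or on a ring already bearing other groups, as in compound 2.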